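A few compounds are considered here, and "the series" means these few. Any claim that something is new, unique, unknown or untested is made for them only; others in the source may bear on it.

Numbers in an assay on isolated protein for inhibition of protein deacetylase HDAC6 (Homo sapiens), read by fluorescence, with stated times of 10 min and 2 h; on this read-out lower numbers stand for stronger inhibition and higher numbers for weaker inhibition:

- compound 1, `O=C(NO)c1ccc(CN2C(=O)CN(Cc3ccccc3)C2=O)cc1`: 12.5 nM
- compound 2, `O=C(NO)c1ccc(CN2C(=O)NC(Cc3ccccc3)(c3ccccc3)C2=O)cc1`: 71.9 nM
- compound 3, `O=C(NO)c1ccc(CN2C(=O)NC(Cc3ccc(Cl)cc3)(c3ccccc3)C2=O)cc1`: 54 nM

Compound 3 stands second highest of the three numbers. Its nearest neighbour is compound 2; the step of a 1.3-fold lower number from compound 2 to compound 3 (0.12 log units; within the scatter) stays within the scatter. Going by the values given here, compound 1 gives the lowest number of the set, and the gap between compound 1 and compound 3 lies beyond the scatter; no single-point step connects them.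

Compound 4, `O=C(NO)c1ccc(CN2C(=O)NC(CCc3ccccc3)(c3ccccc3)C2=O)cc1`, differs from compound 3 by benzyl in place of 4-chlorophenyl on a saturated chain carbon bound to a saturated ring carbon. Two parts can be read into this: the chlorine goes, and the chain grows by one carbon. Only the first part has a measured counterpart, the step of a 1.3-fold lower number from compound 2 to compound 3 (0.12 log units; within the scatter), which was within the scatter, so its reversal is expected to count for little. Among the compounds with values here, for the chain extension no measured step exists. On this basis no step beyond the scatter is expected in this assay, and the estimate for compound 4 is 70 nM, between 25 nM and 200 nM, a step of a 1.3-fold higher number from compound 3 to compound 4 (0.11 log units; within the scatter).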

Compound 4, half-maximal inhibitory concentration: 24.7 nM
Compound 4: middle estimate off by 2.8-fold (0.45 log units), on the high side; the measured number lies below the stated range.
By their numbers in this assay, from the lowest: compounds 1 and 4 (each within the scatter of the next); then compounds 3 and 2 (each within the scatter of the next).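

At this position in this assay, the length of the chain matters in a way the chlorine did not: benzyl in place of phenyl gives a 2.9-fold lower number from compound 2 to compound 4 (0.46 log units; beyond the scatter), while chloro in place of hydrogen gave only a 1.3-fold lower number from compound 2 to compound 3 (0.12 log units; within the scatter), within the scatter. The step of a 2.2-fold lower number from compound 3 to compound 4 (0.34 log units; beyond the scatter) is also beyond the scatter, but it combines loss of the chlorine with the longer chain, so the comparison without chlorine is the cleaner reading of the chain change. No supporting data bear on why the number falls with this change.

Going by these compounds, whether a still longer chain, such as 3-phenylpropyl, continues this trend remains open. So does the effect of a chlorine, an amine or a carboxylic acid on the terminal aromatic ring of the phenethyl group.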